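A few compounds are considered here, and "the series" means these few. Any claim that something is new, unique, unknown or untested is made for them only; others in the source may bear on it.

Measured compounds in the series:

- compound 1 `CCCNC(=O)Nc1cc2nc(C3CCCCC3)[nH]c2cc1N1CCCC1`: in an ADME assay on Vero cells (Chlorocebus sabaeus) for cytotoxicity, read by resazurin assay, with a stated time of 3 days (a higher number here means a weaker inhibitor, a lower number a stronger inhibitor), compound 1 gives > 100 ug/mL, which is a limit of the assay and not a number.
- compound 2 `CCN(CC)c1cc2[nH]c(C3CCCCC3)nc2cc1NC(=O)c1ccc(OC(F)F)cc1`: in this assay compound 2 gives > 100 ug/mL, again a limit.
- compound 3 `CN(C)c1cc2[nH]c(C3CCCCC3)nc2cc1NC(=O)c1ccc(OC(F)F)cc1`: in this assay compound 3 gives > 100 ug/mL, also a limit.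

Compound 3 therefore stands at the assay limit, and so does every other compound shown (the limit of > 100 ug/mL in this assay, at which 3 of the 3 values shown sit). Going by the values given here, the one step between measured compounds that differ in one place, a step that the two limits leave unreadable from compound 2 to compound 3, cannot be read because both ends are limits, so nothing numerical is known about how the substituent on the shared core moves the read-out.

Compound 4 `Cc1ccc(C(=O)Nc2cc3nc(C4CCCCC4)[nH]c3cc2N(C)C)cc1` differs from compound 3 as follows: methyl in place of difluoromethoxy on an aromatic carbon. Among the compounds with values here, no measured step touches the 4-(difluoromethoxy)phenyl group, so no measured step bears directly on this change. What the three values shown offer is that compounds 1, 2 and 3 all sit at the limit (the limit of > 100 ug/mL in this assay, at which 3 of the 3 values shown sit), with no indication of a readable response to any change so far.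

On that basis no step beyond the scatter is expected in this assay, in either direction. Compound 4 is estimated to give 150 ug/mL, with a range from 70 ug/mL to 500 ug/mL, most likely reported as a limit. The step this implies, a step that the limit leaves unreadable from compound 3 to compound 4, is expected to lie within the scatter.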

Compound 4, half-maximal inhibitory concentration: > 100 ug/mL
Compound 4: no number, only a limit; the forecaster's own chance of this, stated with the estimate: 85%; the middle value lies beyond the limit too.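

In this assay compound 4 gives > 100 ug/mL as a limit of the assay and not a number. No step can be read from compound 3 to compound 4, with both ends at the limit: the limit of > 100 ug/mL in this assay, at which 4 of the 4 values shown sit. The compounds shown leave open whether changing 4-(difluoromethoxy)phenyl to 4-methylphenyl, or any other change on the shared core, moves the read-out at all.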